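Chloro for fluoro on the 4-fluorophenyl group

The source may hold more compounds than are shown below. What is called first, only, known or untested is meant among the compounds shown, and "the series" means these compounds.

In a functional assay on MCF7 cells (Homo sapiens) for antiproliferative activity, read by MTT assay, with a stated time of 48 h (on this read-out higher numbers stand for weaker inhibition and lower numbers for stronger inhibition), compound 1 (`Fc1ccc(-c2nn(-c3ccccc3)cc2-c2nc3cc(F)ccc3[nH]2)cc1`) gives 950 nM and compound 3 (`COc1ccc2[nH]c(-c3cn(-c4ccccc4)nc3-c3ccc(F)cc3)nc2c1`) gives 970 nM, and these two do not separate: a 1.0-fold higher number from compound 1 to compound 3 (0.01 log units; within the scatter). Compound 2 (`Fc1ccc(-c2nn(-c3ccccc3)cc2-c2nc3cc(Cl)ccc3[nH]2)cc1`) gives 2230 nM, the highest number of the three.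

Compound 4 (`Clc1ccc(-c2nn(-c3ccccc3)cc2-c2nc3cc(Cl)ccc3[nH]2)cc1`) differs from compound 2 in one place: chloro in place of fluoro on an aromatic carbon. The change is 4-fluorophenyl to 4-chlorophenyl, on a six-membered aromatic ring of carbon only, para to a large group.

The closest evidence is the same exchange made elsewhere in the molecule, a modest step: a 2.3-fold higher number from compound 1 to compound 2 (0.37 log units; beyond the scatter). The methoxy step a 2.3-fold lower number from compound 2 to compound 3 (0.36 log units; beyond the scatter) involves a different group and bears on this change only weakly. For the measured compounds named here, no measured pair makes the exchange on the 4-fluorophenyl group itself, so the transfer is uncertain. A modest rise, no larger than the earlier chloro step, is therefore expected, and the expected step is a 1.4-fold higher number from compound 2 to compound 4 (0.16 log units; within the scatter). Compound 4 is estimated at 3200 nM, with an expected range of 1300 nM to 6500 nM.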

Compound 4, half-maximal inhibitory concentration: 1170 nM
Estimate against measurement, compound 4: 2.7-fold (0.44 log units) above; measured number below the stated range.
By their numbers in this assay, from the lowest: compounds 1, 3, 4 and 2 (each within the scatter of the next, the first and the last beyond it).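

On the 4-fluorophenyl group, chloro in place of fluoro gives a 1.9-fold lower number from compound 2 to compound 4 (0.28 log units; within the scatter) in this assay, so at this position the exchange does not separate the two compounds on this read-out. The same exchange elsewhere in the molecule gave a 2.3-fold higher number from compound 1 to compound 2 (0.37 log units; beyond the scatter), so the result of this exchange in the series depends on where it is made, though the evidence is one pair at each place. Nothing measured here accounts for the contrast between the two places.

For the compounds shown here, whether 4-chlorophenyl behaves the same way alongside the other substituents of compound 1 and compound 3 remains open, as no pair tests it. Also open, from the compounds shown here alone, is how this para position responds to groups further from fluoro and chloro, such as an amine, a carboxylic acid or a longer alkyl chain.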